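The compounds below may be only part of what the source reports. "The series", "measured", "known", "first", "only" and "open" are said of these compounds alone.

Compound 1 `COc1cc(C(c2ccc(O)c(OC)c2)[C@@H](C)[C@@H](C)CF)ccc1O` carries a 2-(fluoromethyl)-1-methylpropyl group on the saturated chain carbon bound to two aromatic carbons. In a functional assay on HL-60 cells (Homo sapiens) for cytotoxicity, read by WST assay, with a stated time of 48 h (a higher number here means a weaker inhibitor, a lower number a stronger inhibitor), compound 1 gives 38000 nM, the highest of the two numbers in hand. Compound 3 `CCCCCCCC[C@H](C(C)C)C(c1ccc(O)c(OC)c1)c1ccc(O)c(OC)c1` gives 3700 nM in this assay, a lower number that lies beyond the scatter of repeated measurements. Compound 2 `COc1ccc(C(c2ccc(OC)c(OC)c2)[C@@H](C)[C@H](C)CO)cc1OC` gives only (the limit of > 100000 nM in this assay, at which 1 of the 3 values shown sits); its result in this assay is the limit > 100000 nM and not a number.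

Compound 4 `COC[C@@H](C)[C@@H](C)C(c1ccc(O)c(OC)c1)c1ccc(O)c(OC)c1` has not yet been measured in this assay. Relative to compound 1 it differs as follows: 2-(methoxymethyl)-1-methylpropyl in place of 2-(fluoromethyl)-1-methylpropyl on a saturated chain carbon bound to two aromatic carbons. Among the compounds with values here, no pair of measured compounds isolates this change, so no measured step can be pointed to. The expected step in this assay is small, if any, with the weaker side judged somewhat more likely: a 1.3-fold higher number from compound 1 to compound 4 (0.12 log units; within the scatter). Compound 4 is accordingly estimated at 50000 nM in this assay, within a range of 15000 nM to 150000 nM.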

Compound 4, half-maximal inhibitory concentration: 85000 nM
Beside the measured number, compound 4's estimate is 1.7-fold (0.23 log units) below it, and the stated range covers the measured number.
By their numbers in this assay, from the lowest: compound 3; then compound 1; then compound 4. At a limit, above all of these: compound 2.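

At the saturated chain carbon bound to two aromatic carbons, the series now has a single readable step: in this assay, 2-(methoxymethyl)-1-methylpropyl in place of 2-(fluoromethyl)-1-methylpropyl gives a 2.2-fold higher number from compound 1 to compound 4 (0.35 log units; beyond the scatter). The earlier compounds shown here isolated no change at this position, whereas this pair shows that a swap at the end of this side group alone can move the number modestly beyond the scatter. The data shown give no reason for this step.

Still open, from the compounds shown here alone, is how an aminomethyl group or a carboxylic acid at the same end of this side group would read in this assay. Also open, going by these compounds, is whether the step from fluoromethyl to methoxymethyl would carry over to a core with a different pattern of ring substituents.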